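The source may hold more compounds than are shown below. What is called first, only, known or untested is meant among the compounds shown, and "the series" means these compounds.

Series notes. Compound 1 `Cc1ccc(NC(=S)NC(=O)c2ccc(OCc3ccccc3)cc2)cc1-c1nc2ccccc2[nH]1` is the thiourea parent carrying an unsubstituted benzyloxy group; in a functional assay on MGC-803 cells (Homo sapiens) for inhibition, read by MTT assay, with a stated time of 48 h (on this read-out lower numbers stand for stronger inhibition and higher numbers for weaker inhibition), compound 1 gives 60700 nM. Compound 2 `Cc1ccc(NC(=S)NC(=O)c2ccc(OCc3ccccc3Cl)cc2)cc1-c1nc2ccccc2[nH]1` carries the change chloro in place of hydrogen on an aromatic carbon on that ring, and in this assay compound 2 gives 45000 nM. The step of a 1.3-fold lower number from compound 1 to compound 2 (0.13 log units; within the scatter) is small, so the two readings are not separable here.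

Compound 3 `Cc1ccc(NC(=O)NC(=O)c2ccc(OCc3ccccc3)cc2)cc1-c1nc2ccccc2[nH]1` replaces the thiourea of compound 1 with a urea while keeping the benzyloxy group; the difference between the two cores is not broken down here. In this assay, for the measured compounds named here, compound 3 gives 39400 nM, a reading that sits close to those of compound 1 and compound 2, with no gap between any pair that exceeds the usual run-to-run spread.

Compound 4 `Cc1ccc(NC(=O)NC(=O)c2ccc(OCc3cccc(Cl)c3)cc2)cc1-c1nc2ccccc2[nH]1` is the urea counterpart in which the change chloro in place of hydrogen on an aromatic carbon is made. The entering group is the same as in the thiourea pair, but its place differs: meta to a large group in compound 4, ortho to a large group in compound 2. Going by the values given here, it is therefore the same kind of change, not the same one, and it has been seen only once so far.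

The expectation is a step of a 1.2-fold lower number from compound 3 to compound 4 (0.08 log units; within the scatter) from compound 3 to compound 4, placed beside the step of a 1.3-fold lower number from compound 1 to compound 2 (0.13 log units; within the scatter) seen in the thiourea pair, because a 1.3-fold lower number from compound 1 to compound 2 (0.13 log units; within the scatter) was itself within the scatter and offers no ground for a larger effect. Compound 4 is accordingly estimated at 33000 nM, with a likely range from 15000 nM to 70000 nM.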

Compound 4, half-maximal inhibitory concentration: 20800 nM
Beside the measured number, compound 4's estimate is 1.6-fold (0.20 log units) above it; low and high end bracket the measured number.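

In this assay the chloro in place of hydrogen on the urea core gives a 1.9-fold lower number from compound 3 to compound 4 (0.28 log units; within the scatter) and, set beside the thiourea pair, the two steps cannot be told apart: the same change on two cores in this assay, a 1.3-fold lower number (0.13 log units; within the scatter) from compound 1 to compound 2 and a 1.9-fold lower number (0.28 log units; within the scatter) from compound 3 to compound 4, 1.4-fold (0.15 log units) apart, within the scatter of two such steps. Within this pair of cores, the change therefore carries over without any detectable dependence on whether the core is the thiourea or the urea, but this is a statement of no visible difference, not proof that the effect is the same, and neither step separates from the scatter, so no gain from chloro is established on either core. The comparison is also not strictly one of identical changes, since compound 4 holds a 3-chlorobenzyl group while the chloro of compound 2 stands at another place on that ring, and two pairs make no general rule for the series.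

Still open, on these data alone, is how a chloro at one fixed place on that ring reads across both cores, which would separate the effect of the core from that of the place. Also open, as far as these compounds go, is whether a different group on that ring, such as a methoxy group, an amine or a carboxylic acid, would give a step that clears the scatter on either core.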